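The source may report more compounds than this note shows. Statements on the series, on what has been measured and on what is new or still open speak of the compounds shown alone.

Measured in a functional assay on OVCAR-3 cells (Homo sapiens) for antiproliferative activity, read by MTT assay, with a stated time of 24 h; a higher number here means a weaker inhibitor, a lower number a stronger inhibitor:
- Compound 1 `Cc1cccc(-n2cc(-c3ccc(NS(=O)(=O)c4c[nH]c(=O)[nH]c4=O)cc3)nn2)c1`: 7490 nM
- Compound 2 `Cc1ccc(-n2cc(-c3ccc(NS(=O)(=O)c4c[nH]c(=O)[nH]c4=O)cc3)nn2)cc1`: 5630 nM

On these numbers, compound 2 cannot be told apart from compound 1, and the gap between the two lies within the scatter. Compound 3 `O=c1[nH]cc(S(=O)(=O)Nc2ccc(-c3cn(-c4ccccc4Cl)nn3)cc2)c(=O)[nH]1`, not yet measured, keeps the shared core and differs from compound 2 only in the group on an aromatic nitrogen: 2-chlorophenyl in place of 4-methylphenyl on an aromatic nitrogen. In short, 2-chlorophenyl stands in place of 4-methylphenyl.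

Going by the values given here, only one measured step bears on this change: a 1.3-fold lower number from compound 1 to compound 2 (0.12 log units; within the scatter). It concerns the same place on the molecule, where 4-methylphenyl replaces 3-methylphenyl, and it stays within the scatter. Among the compounds with values here, no measured compound carries a chlorine, so this step is only a weak guide to what 2-chlorophenyl will do. No shift beyond the scatter is therefore expected in this assay, and neither direction can be favoured. The expected step is a 1.1-fold higher number from compound 2 to compound 3 (0.03 log units; within the scatter). For compound 3 the estimated value is 6000 nM, with an expected range from 2500 nM to 15000 nM.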

Compound 3, half-maximal inhibitory concentration: 4270 nM
Compound 3: middle estimate off by 1.4-fold (0.15 log units), on the high side, within the range that was stated.
By their numbers in this assay, from the lowest: compounds 3, 2 and 1 (each within the scatter of the next).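

In this assay, 2-chlorophenyl brings the first chlorine into the series, yet the step from the methyl-bearing compound stays within the scatter (a 1.3-fold lower number from compound 2 to compound 3 (0.12 log units; within the scatter)). The comparison with the other methyl-bearing compound reads the same way (a 1.8-fold lower number from compound 1 to compound 3 (0.24 log units; within the scatter)), so a chlorine in place of a methyl group, placed differently on the phenyl ring, produces no change that can be told apart from repeat-measurement noise at this position. Nothing available explains why these three groups cannot be separated.

On these data alone, all three compounds carry a substituted phenyl ring on the aromatic nitrogen, so it remains open whether a group of a different kind there, such as an amine, a carboxylic acid or a longer alkyl chain, would shift the number beyond the scatter. As far as these compounds go, it also remains open whether unsubstituted phenyl, or a ring bearing fluorine or a methoxy group, would stay within the same narrow band.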